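This account rests on a few compounds, and the source may have more. Where it says the series, first, only, none or still open, it means among the compounds named here.

Working notes on the series in a functional assay on EL4 cells (Mus musculus) for inhibition, tested at 100 uM; a higher number here means more inhibition at the concentration tested (going by the name of the read-out), a lower number less inhibition.

Three compounds carry a number or a limit so far. Compound 1 `[O-][n+]1ccc2[nH]cnc2c1` gives 5% in this assay. Compound 3 `CN(C)c1[nH]ccc2ncnc1-2` gives 25% in this assay. Compound 2 `CSc1nccc2c1ncn2C1O[C@H](CO)[C@@H](O)[C@H]1O` returns only a limit in this assay, < 5%, and that reading is not a number. Among the measured compounds shown here, compound 2 is the one compound that sits at the limit of < 5% in this assay, at which 1 of the 3 values shown sits, in this assay. For the measured compounds named here, no two of the three compounds differ in a single place, so no measured step is available to weigh the next change against.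

Compound 4 `OC[C@H]1OC(n2cnc3c(Cl)nccc32)[C@H](O)[C@@H]1O` is the next compound and has not been measured in this assay. Relative to compound 2 the change is chloro in place of methylsulfanyl on an aromatic carbon. Going by the values given here, nothing among the measured compounds shows what such a change does in this assay, and compound 2 itself provides only a limit to start from. The step from compound 2 is therefore expected to be small, no larger than the usual scatter, with compound 4 expected to move by a number at least 3 percentage points higher from compound 2 to compound 4 (that floor lies within the scatter). Compound 4 is estimated at 8% in this assay, within a range from 0% to 25%, and a second limit rather than a number is about as likely as not.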

Compound 4, a percentage reported as inhibition, at one concentration (the size of the read-out at that concentration, not a potency): < 5%
Compound 4 ended at the assay's limit (the forecaster's own chance of this, stated with the estimate: 50%); middle value at least 3 percentage points from the limit.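

Compound 2 and compound 4 both return a limit rather than a number in this assay, so no step can be read between them. They share the same reading: the limit of < 5% in this assay, at which 2 of the 4 values shown sit.

The compounds shown leave open whether chloro in place of methylsulfanyl on an aromatic carbon changes the inhibition in this assay at all.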